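A few compounds are considered here, and "the series" means these few. Any claim that something is new, unique, unknown or untested is made for them only; others in the source may bear on it.

Among the measured compounds shown here, the three compounds measured so far share one core and are compared in a functional assay on CHO cells for inhibition of transient receptor potential cation channel subfamily V member 1 (Homo sapiens); a lower number here means a stronger inhibitor, a higher number a weaker inhibitor. Compound 1 `CC(C)(C)c1ccc(/C(=C/C(=O)Nc2ccc3c(c2)OCCO3)c2cccnc2)cc1` gives 78 nM. Compound 2 `CN(C)CCC/C(=C\C(=O)Nc1ccc2c(c1)OCCO2)c1ccc(C(C)(C)C)cc1` differs from compound 1 in one place, and compound 2 gives 3900 nM. That change, 3-(dimethylamino)propyl in place of pyridin-3-yl on a double-bonded chain carbon bound to an aromatic carbon and a double-bonded chain carbon, produced a 50-fold higher number from compound 1 to compound 2 (1.70 log units; beyond the scatter). Compound 3 `Cc1nc(C(F)(F)F)ccc1/C=C/C(=O)Nc1ccc2c(c1)OCCO2` gives 360 nM, the second highest of the three numbers: it lies closest to compound 1 and well apart from compound 2, both gaps beyond the scatter.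

Compound 4 `O=C(/C=C/c1ccc(C(F)(F)F)nc1N1CCCCC1)Nc1ccc2c(c1)OCCO2` is the unmeasured compound. Its difference from compound 3 is piperidin-1-yl in place of methyl on an aromatic carbon, a carbon next to the ring nitrogen, ortho to a large group and meta to a trifluoromethyl group. For the measured compounds named here, the only measured step, from compound 1 to compound 2, sits at a different place, on the chain rather than on the ring, and carries an open amine chain, so it does not bear directly on this change; it shows only that a change near that part of the molecule can move the number a great deal. Going by the values given here, with no closer precedent, a modest move in either direction is expected, a 1.2-fold lower number from compound 3 to compound 4 (0.08 log units; within the scatter). Compound 4 is therefore estimated at 300 nM, within a range from 70 nM to 1300 nM.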

Compound 4, half-maximal inhibitory concentration: 27 nM
Compound 4: the middle estimate sits 11-fold (1.05 log units) above what was measured; the whole stated range lies above it.
By their numbers in this assay, from the lowest: compound 4; then compound 1; then compound 3; then compound 2.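

In this assay, the aromatic carbon that carries methyl in compound 3 also accepts a much larger group: piperidin-1-yl brings 6 heavy atoms and a six-membered non-aromatic ring where methyl has 1 heavy atom and no ring, and the change gives a 13-fold lower number from compound 3 to compound 4 (1.12 log units; beyond the scatter). Among the compounds shown here, none of the earlier compounds had a measured change at this carbon, next to the ring nitrogen, so this pair is the first to show that the number here responds strongly to what is attached and that a larger group can lower it, although this rests on a single pair of compounds. For the compounds shown here, nothing available measures why this swap lowers the number so far, so the step stands as an observation without an explanation.

On these data alone, it remains open whether the lower number goes with the ring of piperidin-1-yl or with its nitrogen bound to the aromatic carbon: a dimethylamino group would keep that nitrogen without the ring, while a cyclohexyl group would keep a six-membered ring without the nitrogen. Morpholin-4-yl, which adds an oxygen to the ring, would show whether a second hetero atom in that ring is accepted at this carbon.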